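This account rests on a few compounds, and the source may have more. Where it says the series, first, only, none or still open, it means among the compounds named here.

Measured in a functional assay on SK-OV-3 cells (Homo sapiens) for antiproliferative activity, read by MTT assay, with a stated time of 24 h; on this read-out lower numbers stand for stronger inhibition and higher numbers for weaker inhibition:
- compound 1 `COc1ccc(C(=O)/C=C/c2cccc([N+](=O)[O-])c2)c2c1C=CC(C)(C)O2` gives 9720 nM
- compound 2 `COc1ccc(C(=O)/C=C/c2ccc(Cl)cc2)c2c1C=CC(C)(C)O2` gives > 10000 nM (a limit)

Compound 2 has only a limit of the assay, not a number, namely > 10000 nM. This is the limit of > 10000 nM in this assay, at which 1 of the 2 values shown sits.

Compound 3 `COc1ccc(C(=O)/C=C/c2cccc(Cl)c2)c2c1C=CC(C)(C)O2` differs from compound 2 as follows: 3-chlorophenyl in place of 4-chlorophenyl on a double-bonded chain carbon bound to a double-bonded chain carbon. Going by the values given here, the one measured step that bears on this change is an at least 1.0-fold higher number from compound 1 to compound 2 (0.01 log units; that floor lies within the scatter). On that basis, no step beyond the scatter is expected in this assay, and the expected step is a number no higher from compound 2 to compound 3 (the limit leaves the size open). For compound 3 the estimated value is 10000 nM, with an expected range of 5000 nM to 20000 nM.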

Compound 3, half-maximal inhibitory concentration: > 10000 nM
Compound 3 gave a limit, no number; the forecaster's own chance of this, stated with the estimate: 60%; the middle value lies on the limit itself.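

In this assay compound 3 gives > 10000 nM as a limit and not a number, and the series gathers there: the limit of > 10000 nM in this assay, at which 2 of the 3 values shown sit. The move from 4-chlorophenyl to 3-chlorophenyl cannot be read, as compound 2 and compound 3 both stand at a limit. Chloro in place of nitro on an aromatic carbon gives an at least 1.0-fold higher number from compound 1 to compound 3 (0.01 log units; that floor lies within the scatter) and so shows no step beyond the scatter, with its full size left open by the limit.

Still open, going by these compounds, is whether an amine or a carboxylic acid on that aromatic ring would give a readable number in this assay. Also open, on these data alone, is how far compound 2 and compound 3 truly differ.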